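The source may hold more compounds than are shown below. What is called first, only, known or untested is meant among the compounds shown, and "the series" means these compounds.

Working notes on the urea series.

Compound 1 `Cc1cccc(NC(=O)N[C@H](C)c2ccccc2)c1` is read in an ADME assay on the whole organism with Oryza sativa as the target, tested at 1 uM (on this read-out higher numbers stand for a weaker effect at the one concentration tested and lower numbers for a stronger effect), where compound 1 gives 98%. Its enantiomer compound 2 `Cc1cccc(NC(=O)N[C@@H](C)c2ccccc2)c1` gives 100% in this assay, and compound 3 `C[C@@H](NC(=O)Nc1ccccc1I)c1ccccc1` gives 100% in this assay; both of these numbers lie within the usual scatter of the number for compound 1, so no ordering among the three is supported.

Within the data shown here, the only step between measured compounds that differ in one place is a number 2 percentage points higher from compound 1 to compound 2 (within the scatter), and it rests on (the fact that compounds 1 and 2 differ only in the configuration as drawn); it shows that inversion of the stereocentre leaves the read-out unchanged, but it says nothing about a substituent swap on the aryl ring.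

Compound 4 `C[C@@H](NC(=O)Nc1cccc(I)c1)c1ccccc1` is the next compound for this assay. It differs from compound 1 by iodo in place of methyl on an aromatic carbon. Among the measured compounds shown here, no measured step addresses this exchange, and the three numbers so far all sit close together near the top of the scale, so no change beyond the scatter is expected: the step from compound 1 to compound 4 is estimated at a number 1 percentage points higher from compound 1 to compound 4 (within the scatter). Compound 4 is expected to give 99%, with a range from 90% to 100%, in this assay.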

Compound 4, a percentage reported as activity, at one concentration (the size of the read-out at that concentration, not a potency): 75%
Estimate against measurement, compound 4: 24 percentage points above, outside the stated range (below it).
By their numbers in this assay, from the lowest: compound 4; then compounds 1, 2 and 3 (each within the scatter of the next).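

In this assay, among these compounds, iodo in place of methyl on an aromatic carbon, meta to a large group, is the first change to move the read-out beyond the scatter: a number 23 percentage points lower from compound 1 to compound 4 (beyond the scatter). Compound 3 also carries iodo, at a different place on the ring, and gives 100%, so the presence of iodo alone does not go with the stronger effect seen for compound 4. Nothing available gives a cause for this step.

From the compounds shown here alone, whether chloro, bromo or methoxy at this same place would also give a stronger effect than methyl remains open. Also open is whether the configuration of the stereocentre matters once iodo is present, as the one inversion step shown carries methyl on the ring.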